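A second ring-bearing group on a carbonyl carbon

A few compounds are considered here, and "the series" means these few. Any claim that something is new, unique, unknown or untested is made for them only; others in the source may bear on it.

compound 1 `Cc1c(C)c2c(c(C)c1OC(=O)CCC(=O)O)CCC(C)(C(=O)NC1CC(C)(C)N([O])C(C)(C)C1)O2` gives 123000 nM
compound 2 `Cc1c(C)c2c(c(C)c1OC(=O)CCC(=O)O)CCC(C)(C(=O)O)O2` gives 120000 nM

Both values come from a functional assay on U-937 cells (Homo sapiens) for cytotoxicity, read by MTT assay, with a stated time of 72 h (a higher number here means a weaker inhibitor, a lower number a stronger inhibitor), and compound 1 stands level with compound 2 within the scatter. Compound 3 `Cc1c(C)c2c(c(C)c1OC(=O)CCC(=O)NC1CC(C)(C)N([O])C(C)(C)C1)CCC(C)(C(=O)NC1CC(C)(C)N([O])C(C)(C)C1)O2` follows from compound 1 through a group of 12 heavy atoms (9 carbon, 2 nitrogen, 1 oxygen; one six-membered non-aromatic ring with 1 hetero atom) in place of one oxygen atom, on a carbonyl carbon and nothing else changes. Within the data shown here, the one measured step that bears on this is a 1.0-fold lower number from compound 1 to compound 2 (0.01 log units; within the scatter) and it concerns the same group on a carbonyl carbon, so for compound 1 no change beyond the scatter is expected in this assay on this thin evidence. The expected result is a 1.1-fold lower number from compound 1 to compound 3 (0.05 log units; within the scatter) and no more. Compound 3 is estimated at 110000 nM with a range from 50000 nM to 220000 nM as expected bounds.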

Compound 3, half-maximal inhibitory concentration: 72000 nM
Compound 3: middle estimate off by 1.5-fold (0.18 log units), on the high side, and the stated range covers the measured number.
By their numbers in this assay, from the lowest: compounds 3, 2 and 1 (each within the scatter of the next).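

In this assay, putting the ring-bearing group in place of the hydroxy on the carbonyl carbon whose other neighbour is a saturated chain carbon gives a 1.7-fold lower number from compound 1 to compound 3 (0.23 log units; within the scatter). Among these compounds, the earlier step concerned the same group on another carbonyl carbon, so this is the first reading at this place, and the two groups together move the number no further than the scatter. No measured evidence offers an explanation for this result. The compounds shown leave open how an amine or a longer chain on this carbonyl carbon would read, and whether the hydroxy and the ring-bearing group are alike in any other cell line.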